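This account rests on a few compounds, and the source may have more. Where it says the series, first, only, none or still open, it means among the compounds named here.

Working notes on the series. Compound 3 `COc1cc(C2=NN(C(C)=O)C(c3ccccc3F)O2)cc(OC)c1OC` gives 13.5% in a functional assay on PC-3 cells (Homo sapiens) for antiproliferative activity, read by MTT assay, tested at 1 uM (on this read-out higher numbers stand for a stronger effect at the one concentration tested and lower numbers for a weaker effect), and stands second highest of the three numbers measured, with compound 2 `COc1cc(C2=NN(C(C)=O)C(c3ccc(F)cc3)O2)cc(OC)c1OC` nearest at 0% and compound 1 `COc1ccc(C2OC(c3cc(OC)c(OC)c(OC)c3)=NN2C(C)=O)c(OC)c1` furthest at 69.5%. The measured steps are a number 69.5 percentage points lower from compound 1 to compound 2 (beyond the scatter), a number 56 percentage points lower from compound 1 to compound 3 (beyond the scatter) and a number 13.5 percentage points higher from compound 2 to compound 3 (beyond the scatter). Compound 4 `COc1cc(C2=NN(C(C)=O)C(c3ccc(Cl)c([N+](=O)[O-])c3)O2)cc(OC)c1OC` differs from compound 3 as follows: 4-chloro-3-nitrophenyl in place of 2-fluorophenyl on a saturated ring carbon. For the measured compounds named here, no measured step exchanges a fluorophenyl for a 4-chloro-3-nitrophenyl on this saturated ring carbon; the only step between two halophenyl groups, a number 13.5 percentage points higher from compound 2 to compound 3 (beyond the scatter), was modest. On that basis a step of comparable size at most is expected in this assay, direction uncertain. Compound 4 is therefore estimated at 15% (range 0% to 40%), a step of a number 1.5 percentage points higher from compound 3 to compound 4 (within the scatter) expected from compound 3.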

Compound 4, a percentage reported as inhibition, at one concentration (the size of the read-out at that concentration, not a potency): 43.3%
Compound 4: the middle estimate sits 28.3 percentage points below what was measured, and the stated range ends below it.
By their numbers in this assay, from the lowest: compound 2; then compound 3; then compound 4; then compound 1.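

A fluorophenyl result does not set the level for every halogen-bearing phenyl at this saturated ring carbon in this assay, since the 4-chloro-3-nitrophenyl group gives a number 29.8 percentage points higher from compound 3 to compound 4 (beyond the scatter) and a number 43.3 percentage points higher from compound 2 to compound 4 (beyond the scatter) in this series. The 2,4-dimethoxyphenyl group still leads, with a number 26.2 percentage points lower from compound 1 to compound 4 (beyond the scatter) for the same position. No measurement shown gives a cause for these differences. The compounds shown do not separate the contribution of the chloro substituent from that of the nitro group. On these data alone, how a 4-aminophenyl or 4-carboxyphenyl group would read at this position remains open.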